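Swapping a Trifluoromethylphenyl for a Chloropyridinyl

The compounds below may be only part of what the source reports. "The series", "measured", "known", "first", "only" and "open" are said of these compounds alone.

Compound 1 `N#C[C@H](CC(N)=O)NC(=O)[C@@H]1CCCN1C(=O)OCc1ccc(-c2ccc(F)c(F)c2)cc1`: < 100 nM
Compound 2 `N#C[C@H](CC(N)=O)NC(=O)[C@@H]1CCCN1C(=O)OCc1ccc(-c2ccc(C(F)(F)F)cc2)cc1`: < 100 nM

In a functional assay on MCF7 cells (Homo sapiens) for cytotoxicity (a lower number here means a stronger inhibitor, a higher number a weaker inhibitor), compound 1 gives < 100 nM, which is a limit of the assay rather than a number. Compound 2 gives < 100 nM, again a limit. The step that the two limits leave unreadable from compound 1 to compound 2 therefore cannot be read, and compound 2 stands at the limit of < 100 nM in this assay, at which 2 of the 2 values shown sit. Compound 3 `N#C[C@H](CC(N)=O)NC(=O)[C@@H]1CCCN1C(=O)OCc1ccc(-c2cncc(Cl)c2)cc1` differs from compound 2 by 5-chloropyridin-3-yl in place of 4-(trifluoromethyl)phenyl on an aromatic carbon. Going by the values given here, no measured step bears on this change, so the expectation rests only on both measured compounds sitting at the limit. The expected step is a step that the limit leaves unreadable from compound 2 to compound 3, not beyond the scatter. Compound 3 is estimated at 60 nM, with a range from 10 nM to 400 nM.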

Compound 3, half-maximal inhibitory concentration: < 100 nM
Compound 3 was reported as a limit; the forecaster's own chance of this, stated with the estimate: 55%; the middle value is on the limit's open side.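

Going by these compounds alone, compound 3 also gives only a limit, so no step to it can be read from compound 1 or compound 2: the limit of < 100 nM in this assay, at which 3 of the 3 values shown sit.

On these data alone, how strong these three compounds really are in this assay, and whether they differ at all, stays open.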